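Ester in place of amide on the carbonyl carbon

The compounds below may be only part of what the source reports. "The series", "measured", "known", "first", "only" and "open" are said of these compounds alone.

Of the compounds shown here, three have been read in an assay on membranes from CHO cells for displacement of a labelled ligand from adenosine receptor A1 (Homo sapiens), read by scintillation counting, with a stated time of 60 min, tested at 1 uM; a lower number here means less inhibition, a higher number more inhibition at the concentration tested (going by the name of the read-out). Compound 1 `CCCOC(=O)C1=C(C)NC(=O)NC1c1ccoc1` gives 50%. Compound 2 `CC1=C(C(=O)CC(C)C)C(c2ccoc2)NC(=O)N1` gives 23%. Compound 3 `CCN(CC)C(=O)C1=C(C)NC(=O)NC1c1ccoc1` gives 15%, the lowest of the three numbers; its step from compound 2 is a number 8 percentage points lower from compound 2 to compound 3 (within the scatter), while the step from compound 1 is a number 35 percentage points lower from compound 1 to compound 3 (beyond the scatter).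

Compound 4 `CCC(CC)OC(=O)C1=C(C)NC(=O)NC1c1ccoc1` differs from compound 3 by (pentan-3-yl)oxy in place of diethylamino on a carbonyl carbon. The change returns the carbonyl carbon from an amide to an ester, so the relevant measured step is the one from the ester of compound 1 to the amide of compound 3, a number 35 percentage points lower from compound 1 to compound 3 (beyond the scatter), now run in reverse; the step of a number 27 percentage points lower from compound 1 to compound 2 (beyond the scatter) points the same way in that leaving the propoxy ester lowered the number. Among the compounds with values here, the branched alkoxy group of compound 4 has no measured precedent, so some room is left on either side of compound 1.

In this assay compound 4 is therefore expected to rise by a number 30 percentage points higher from compound 3 to compound 4 (beyond the scatter), to about 45%, estimated between 25% and 65%.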

Compound 4, a percentage reported as inhibition, at one concentration (the size of the read-out at that concentration, not a potency): 17%
Compound 4: the middle estimate sits 28 percentage points above what was measured; measured number outside the range, below it.
By their numbers in this assay, from the lowest: compounds 3, 4 and 2 (each within the scatter of the next); then compound 1.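

In this assay, the ester linkage alone does not bring back the higher number: a number 33 percentage points lower from compound 1 to compound 4 (beyond the scatter), with ethyl in place of hydrogen on the saturated chain carbon bound to the oxygen. The (pentan-3-yl)oxy ester reads as no different from the amide, a number 2 percentage points higher from compound 3 to compound 4 (within the scatter), or from the isobutyl carbonyl compound, a number 6 percentage points lower from compound 2 to compound 4 (within the scatter), so at this carbonyl carbon the propoxy ester of compound 1 stands apart from the three other groups shown. No measured evidence bears on the reason for this result.

Going by these compounds, it remains open how the number runs among alkoxy groups from propoxy to (pentan-3-yl)oxy, for example with an isopropoxy or a butoxy ester. On these data alone, it is equally open whether a shorter chain, such as an ethoxy or methoxy ester, would read as compound 1 does.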